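Trading 1-phenylethyl for a 3-(methylamino)propyl chain

The compounds below may be only part of what the source reports. "The series", "measured", "known", "first", "only" and "open" are said of these compounds alone.

In a functional assay on MDA-MB-435 cells (Homo sapiens) for cytotoxicity, read by MTT assay, with a stated time of 72 h (a lower number here means a stronger inhibitor, a higher number a weaker inhibitor), compound 1 `NCCCNc1c(C(=O)NCc2ccc(F)cc2)nc(Br)c2cccnc12` gives 5000 nM. Compound 2 `C[C@H](Nc1c(C(=O)NCc2ccc(F)cc2)nc(Br)c2cccnc12)c1ccccc1` gives > 20000 nM, which is a limit and not a number. Compound 2 therefore stands at the limit of > 20000 nM in this assay, at which 1 of the 2 values shown sits. Compound 3 `CNCCCNc1c(C(=O)NCc2ccc(F)cc2)nc(Br)c2cccnc12` has 3-(methylamino)propyl in place of 1-phenylethyl on a nitrogen on an aromatic ring. For the measured compounds named here, one measured step bears on this: an at least 4.0-fold higher number from compound 1 to compound 2 (0.60 log units; beyond the scatter). The entering chain resembles the 3-aminopropyl of compound 1, so a step of similar size towards a lower number is expected. The expected step is an at least 5.0-fold lower number from compound 2 to compound 3 (0.69 log units; beyond the scatter). Compound 3 is estimated at 4000 nM, with an expected range from 1500 nM to 12000 nM.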

Compound 3, half-maximal inhibitory concentration: 11000 nM
Beside the measured number, compound 3's estimate is 2.8-fold (0.44 log units) below it; low and high end bracket the measured number.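

In this assay a single methyl on the amine nitrogen of the chain gives a 2.2-fold higher number from compound 1 to compound 3 (0.34 log units; beyond the scatter) and so modestly weakens the compound. Compound 2 gives > 20000 nM as a limit and not a number. The change from 1-phenylethyl to 3-(methylamino)propyl can therefore be sized only as a floor, an at least 1.8-fold lower number from compound 2 to compound 3 (0.25 log units; that floor lies within the scatter) and no firmer statement follows from it.

As far as these compounds go, whether a dimethylamino end, a longer chain or a hydroxyl in place of the amine would match compound 1 stays open. From the compounds shown here alone, the true value of compound 2 also stays unknown.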